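Removing the methoxy group from compound 3

A few compounds are considered here, and "the series" means these few. Any claim that something is new, unique, unknown or untested is made for them only; others in the source may bear on it.

Compound 3 `COc1ccc2oc(CSC(=S)N(C(C)C)C(C)C)cc(=O)c2c1` was tested in a functional assay on LM7 cells (Homo sapiens) for antiproliferative activity, read by MTT assay, with a stated time of 72 h (on this read-out higher numbers stand for weaker inhibition and lower numbers for stronger inhibition), where compound 3 gives 19100 nM. Its closest neighbour is compound 1 `COc1ccc2oc(CSC(=S)N3CCOCC3)cc(=O)c2c1`, which in this assay gives 11000 nM. Among the compounds with values here, the one step between measured compounds that differ in a single place is a 1.7-fold higher number from compound 1 to compound 3 (0.24 log units; within the scatter), diisopropylamino in place of morpholin-4-yl on a thiocarbonyl carbon, and it does not separate the two numbers beyond the scatter. Compound 2 `CC(C)N(C(=S)SCc1oc2ccccc2c(=O)c1Cl)C(C)C` is a diisopropylamino analogue that bears a chloro group and no methoxy. In this assay compound 2 is reported only as a limit, > 40000 nM, namely (the limit of > 40000 nM in this assay, at which 1 of the 3 values shown sits).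

Compound 4 `CC(C)N(C(=S)SCc1cc(=O)c2ccccc2o1)C(C)C` differs from compound 3 by hydrogen in place of methoxy on an aromatic carbon. Within the data shown here, no measured step addresses this change, and compound 2 differs from compound 3 in two places and offers only a limit. The step from compound 3 to compound 4 is therefore expected to stay within the scatter, a 1.2-fold higher number from compound 3 to compound 4 (0.06 log units; within the scatter). Compound 4 is accordingly estimated at 22000 nM, with a range from 9000 nM to 45000 nM.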

Compound 4, half-maximal inhibitory concentration: > 25000 nM
Compound 4 gave a limit, no number (the forecaster's own chance of this, stated with the estimate: 30%); at least 1.1-fold (0.05 log units) between middle value and limit.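

Compound 4 is reported only as a limit, not a number: the limit of > 25000 nM in this assay, at which 1 of the 4 values shown sits. Hydrogen in place of methoxy on this aromatic carbon gives an at least 1.3-fold higher number from compound 3 to compound 4 (0.11 log units; that floor lies within the scatter), the first measured step at this position, so the change shows no stronger inhibition, while its floor does not establish a loss of activity. The step from compound 2 to compound 4 cannot be read, as both values are limits.

As far as these compounds go, how far the true value of compound 4 lies past its limit remains open, and so does whether removing the methoxy group would act alike with the morpholin-4-yl group of compound 1 in place of diisopropylamino. Also open, from the compounds shown here alone, is how an ethoxy or a hydroxyl group on this same aromatic carbon would compare with methoxy.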